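The source may hold more compounds than are shown below. What is called first, only, known or untested is meant among the compounds shown, and "the series" means these compounds.

In a functional assay on a cell-free system (plasma, Oryctolagus cuniculus) for inhibition, with stated times of 5 min, 1 min and 6 min (on this read-out higher numbers stand for weaker inhibition and lower numbers for stronger inhibition), compound 1 `CCOC(=O)c1[nH]c(-c2cccc(C#N)c2)nc1C`, with hydrogen on an aromatic nitrogen of the shared core, gives > 30000 nM, which is a limit of the assay and not a number. Compound 2 `CCOC(=O)c1c(C)nc(-c2cccc(C#N)c2)n1C` carries methyl at that place and gives 22100 nM. Compound 3 `CCOC(=O)c1c(C)nc(-c2cccc(C#N)c2)n1OC(C)C` carries isopropoxy there and gives 6740 nM, the lower of the two true numbers in this small set.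

Compound 4 `C=CCOn1c(-c2cccc(C#N)c2)nc(C)c1C(=O)OCC` keeps all of compound 3 except for one change, allyl in place of isopropyl on an oxygen on an aromatic ring.

For the measured compounds named here, no measured step makes this exact change, so the evidence is indirect. Methyl in place of hydrogen gave an at least 1.3-fold lower number from compound 1 to compound 2 (0.13 log units; that floor lies within the scatter). Isopropoxy in place of hydrogen gave an at least 4.4-fold lower number from compound 1 to compound 3 (0.64 log units; beyond the scatter). Isopropoxy in place of methyl gave a 3.3-fold lower number from compound 2 to compound 3 (0.52 log units; beyond the scatter). Going by the values given here, all three steps replace the whole group on the nitrogen, and even the last of them, the only one between two true numbers, is modest. The new change is milder, since the oxygen stays and the group on it keeps the same count of heavy atoms. The expected outcome is a 1.0-fold higher number from compound 3 to compound 4 (0.02 log units; within the scatter), with no shift beyond the scatter in either direction. For compound 4 the estimated value is 7000 nM, with an expected range from 3000 nM to 16000 nM.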

Compound 4, half-maximal inhibitory concentration: 5860 nM
Compound 4: the middle estimate sits 1.2-fold (0.08 log units) above what was measured; measured number inside the range.
By their numbers in this assay, from the lowest: compounds 4 and 3 (each within the scatter of the next); then compound 2. At a limit, above all of these: compound 1.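

In this assay, allyl in place of isopropyl on the oxygen keeps the same count of heavy atoms and adds one double bond outside aromatic rings, and it gives a 1.2-fold lower number from compound 3 to compound 4 (0.06 log units; within the scatter), so this change does not separate the two groups at this position. For the compounds shown here, the advantage over methyl on the aromatic nitrogen, until now seen only with isopropoxy as a 3.3-fold lower number from compound 2 to compound 3 (0.52 log units; beyond the scatter), appears again with a second group on the oxygen as a 3.8-fold lower number from compound 2 to compound 4 (0.58 log units; beyond the scatter), which shows that it is not tied to isopropyl alone. Allyloxy in place of hydrogen gives an at least 5.1-fold lower number from compound 1 to compound 4 (0.70 log units; beyond the scatter), a floor and no exact size, as the first value in that step is a limit of the assay and not a number: the limit of > 30000 nM in this assay, at which 1 of the 4 values shown sits.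

With only isopropyl and allyl shown on this oxygen, it stays open whether a longer chain, a benzyl group or a chain ending in an amine or a carboxylic acid would leave the number where it stands or move it. Also open, going by these compounds, is how methoxy, with a single carbon on the oxygen, would compare with isopropoxy and allyloxy.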